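Same Atoms, Joined Differently: From Compound 2 to Compound 3

This account rests on a few compounds, and the source may have more. Where it says the series, first, only, none or still open, it means among the compounds named here.

Among the measured compounds shown here, only two compounds have numbers so far in a functional assay on MDA-MB-231 cells (Homo sapiens) for cytotoxicity, read by MTT assay, with a stated time of 48 h; a lower number here means that less compound is needed, a higher number that more compound is needed for the effect. Compound 1 (`CO[C@H]1O[C@H](COc2ccc3c(c2)CCCC3)[C@@H](O)[C@H](O)[C@H]1Oc1ccc(OC2CCCCC2)cc1`) gives 20000 nM, and compound 2 (`CO[C@H]1O[C@H](COc2ccc(C3CCCCC3)cc2)[C@@H](O)[C@H](O)[C@H]1Oc1cccc2c1CCCC2`) gives 37000 nM. These two numbers lie within the usual scatter of repeated measurements, so compound 2 cannot be ranked against compound 1. The two compounds also differ in more than one place, so their values say nothing about any single change.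

Compound 3 (`CO[C@H]1O[C@H](COc2ccc(C3CCCCC3)cc2)[C@@H](O)[C@H](O)[C@H]1Oc1ccc2c(c1)CCCC2`) has the same atoms as compound 2, joined differently: 1,2,3,4-tetrahydronaphthalen-6-yl in place of 1,2,3,4-tetrahydronaphthalen-5-yl on an oxygen on a saturated carbon. The rest of the molecule stays as it is.

For the measured compounds named here, no measured pair shows what this swap does. Going by the values given here, the only guide is that compound 1 at 20000 nM and compound 2 at 37000 nM sit within the scatter of each other, despite their different groups. The estimated change, a 1.3-fold lower number from compound 2 to compound 3 (0.12 log units; within the scatter), is therefore expected to stay within the scatter of this assay, with no firm direction. For compound 3 the expected value is 28000 nM, with an estimated range from 11000 nM to 70000 nM.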

Compound 3, half-maximal effective concentration: 25000 nM
Compound 3: the middle estimate sits 1.1-fold (0.05 log units) above what was measured; the range from low to high includes it.
By their numbers in this assay, from the lowest: compounds 1, 3 and 2 (each within the scatter of the next).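

In this assay a single change now has a size of its own: a 1.5-fold lower number from compound 2 to compound 3 (0.17 log units; within the scatter) for one group exchanged at one place. Compounds 1 and 2 differ in more than one place and could not show this, whereas here only the way the group is joined differs, with 1,2,3,4-tetrahydronaphthalen-6-yl in place of 1,2,3,4-tetrahydronaphthalen-5-yl on the same oxygen on a saturated carbon, and the two groups cannot be told apart in this assay on this evidence. No separate measurement bears on this result or offers an explanation for it.

Still open, going by these compounds, is whether a different kind of group on that oxygen, such as a plain methyl, a longer chain or a chain ending in an amine, would move the number beyond the scatter. Also open, on these data alone, is whether exchanging these same two groups would again stay within the scatter if the other parts of the molecule were different, as a single pair cannot settle that.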